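The source may hold more compounds than are shown below. What is called first, only, known or untested is meant among the compounds shown, and "the series" means these compounds.

Measured compounds in a functional assay on SW-620 cells (Homo sapiens) for inhibition; a higher number here means a weaker inhibitor, a lower number a stronger inhibitor:
- compound 1 `CC(C)C(NC(=O)NO)C(=O)NC1CCCC1` gives > 100000 nM, a limit of the assay.
- compound 2 `CCC(C)C(NC(=O)n1nnc2ccccc21)C(=O)NC1CCCCC1` gives > 100000 nM, a limit of the assay.
- compound 3 `CC(C)C(NC(=O)n1nnc2ccccc21)C(=O)NC1CCCCC1` gives > 100000 nM, a limit of the assay.

All three measured compounds sit at the same limit in this assay, as shown by the limit of > 100000 nM in this assay, at which 3 of the 3 values shown sit. Compound 3 and compound 2 differ by methyl in place of hydrogen on a saturated chain carbon, three bonds along the chain from an amide-type nitrogen and a carbonyl carbon, and the step that the two limits leave unreadable from compound 3 to compound 2 cannot be read because both values are limits. The difference between the core of compound 1 and the core of compound 3 is not broken down here.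

Compound 4 `CCC(C)C(NC(=O)NO)C(=O)NC1CCCC1` is not yet measured. It differs from compound 1 by methyl in place of hydrogen on a saturated chain carbon, three bonds along the chain from an amide-type nitrogen and a carbonyl carbon, the same kind of change as that between compound 3 and compound 2. Since the measured pair gave no readable step, and compound 1 itself gives only a limit, compound 4 is expected to remain at the limit as well; the step that the limit leaves unreadable from compound 1 to compound 4 is estimated to be essentially nil. Compound 4 is therefore expected to give about 150000 nM in this assay, most likely reported only as a limit, within 50000 nM to 1000000 nM.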

Compound 4, half-maximal inhibitory concentration: > 100000 nM
Compound 4 gave a limit, no number; the forecaster's own chance of this, stated with the estimate: 90%; the middle value is on the limit's open side.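

In this assay compound 4 gives > 100000 nM, a limit of the assay, and compound 1 also gives only a limit, so no step can be read between compound 1 and compound 4. The compounds shown leave open whether methyl in place of hydrogen, or the difference between their cores, changes inhibition at all, since every value is a limit: the limit of > 100000 nM in this assay, at which 4 of the 4 values shown sit.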